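Chain extension on the ring amine across two aryl cores

The source may hold more compounds than are shown below. What is called first, only, known or untested is meant among the compounds shown, and "the series" means these compounds.

Compound 1 `CCN1CC[C@@]2(OC)OC(N)=C(C#N)[C@@H](c3ccc(Cl)cc3)[C@@H]2C1` and compound 2 `CCCN1CC[C@@]2(OC)OC(N)=C(C#N)[C@@H](c3ccc(Cl)cc3)[C@@H]2C1` share one core; compound 3 `CCN1CC[C@@]2(OC)OC(N)=C(C#N)[C@@H](c3ccc(C)cc3)[C@@H]2C1` and the unmeasured compound 4 `CCCN1CC[C@@]2(OC)OC(N)=C(C#N)[C@@H](c3ccc(C)cc3)[C@@H]2C1` share the other. The two cores differ by methyl in place of chloro on an aromatic carbon. In a functional assay on trachea (Cavia porcellus) (on this read-out higher numbers stand for weaker inhibition and lower numbers for stronger inhibition), compound 1 gives 14900 nM, and compound 2 gives 30300 nM; the step between them is a 2.0-fold higher number from compound 1 to compound 2 (0.31 log units; beyond the scatter). Compound 3 gives 16800 nM in this assay, and the step across the cores is a 1.1-fold higher number from compound 1 to compound 3 (0.05 log units; within the scatter), so the two cores behave alike on this read-out. The change from compound 3 to compound 4 is methyl in place of hydrogen on a saturated chain carbon, two bonds along the chain from an amine nitrogen in a ring. It is the same change as the one from compound 1 to compound 2, (methyl in place of hydrogen on a saturated chain carbon, two bonds along the chain from an amine nitrogen in a ring), the place being described in identical words in both cases; the change occurs twice among these compounds and has been measured once. Because the cores lie within the scatter of each other on a 1.1-fold higher number from compound 1 to compound 3 (0.05 log units; within the scatter), a step of similar size is expected for compound 4, namely a 1.9-fold higher number from compound 3 to compound 4 (0.28 log units; within the scatter), resting on the measured step of a 2.0-fold higher number from compound 1 to compound 2 (0.31 log units; beyond the scatter). Compound 4 is therefore estimated at about 32000 nM, expected between 16000 nM and 64000 nM.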

Compound 4, half-maximal inhibitory concentration: 21000 nM
For compound 4 the middle estimate is 1.5-fold (0.18 log units) above the measured one; measured number inside the range.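

In this assay, methyl in place of hydrogen on a saturated chain carbon, two bonds along the chain from an amine nitrogen in a ring, gives a 1.3-fold higher number from compound 3 to compound 4 (0.10 log units; within the scatter), and this step does not differ measurably from the earlier one: the same change on two cores in this assay, a 2.0-fold higher number (0.31 log units; beyond the scatter) from compound 1 to compound 2 and a 1.3-fold higher number (0.10 log units; within the scatter) from compound 3 to compound 4, 1.6-fold (0.21 log units) apart, within the scatter of two such steps

Methyl in place of chloro on an aromatic carbon gives a 1.4-fold lower number from compound 2 to compound 4 (0.16 log units; within the scatter), and this change likewise carries over between the ethyl and propyl compounds: the same change on two cores in this assay, a 1.1-fold higher number (0.05 log units; within the scatter) from compound 1 to compound 3 and a 1.4-fold lower number (0.16 log units; within the scatter) from compound 2 to compound 4, 1.6-fold (0.21 log units) apart, within the scatter of two such steps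

Both changes therefore carry from one core to the other within the scatter in these four compounds, but each comparison rests on a single pair of steps, and the ethyl to propyl step lies beyond the scatter on one core and within it on the other, so a real effect of this change on the core of compound 3 is not shown.

Still open, from the compounds shown here alone, is whether a longer chain, such as butyl, on the amine nitrogen in a ring would follow the same course on both cores. Also open, going by these compounds, is whether a methoxy group or a fluorine on the aromatic carbon would leave the number as little changed as methyl and chloro do.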